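Aryl amide trimming in a urotensin-2 receptor series

The source may hold more compounds than are shown below. What is called first, only, known or untested is meant among the compounds shown, and "the series" means these compounds.

Two compounds define the present range. Compound 1 `CN(C)CCC(OC(=O)c1ccc2ccccc2c1)c1ccc(Cl)cc1`, an ester carrying a naphthyl group, gives 2090 nM in an assay on NIH3T3 cells with Urotensin-2 receptor (Homo sapiens) as the target; a higher number here means that more compound is needed for the effect, a lower number that less compound is needed. Compound 2 `Cc1cccc(C(=O)NC(CCN(C)C)c2ccc(Cl)cc2)c1C`, the amide of the series, gives 3630 nM in this assay; the two values lie within the usual scatter of each other, so neither can be placed in front of the other on the present numbers.

Compound 3 `CN(C)CCC(NC(=O)c1ccccc1)c1ccc(Cl)cc1` keeps the shared core of compound 2 and changes only the aryl group on the amide: phenyl in place of 2,3-dimethylphenyl on a carbonyl carbon. For the measured compounds named here, no measured pair of this kind is available, so the size of the step is open. Compound 3 is expected to land somewhat weaker than compound 2, with the step from compound 2 to compound 3 of about a 1.5-fold higher number from compound 2 to compound 3 (0.18 log units; within the scatter), though a step within the scatter would not be surprising. Compound 3 is therefore estimated at 5500 nM in this assay, with a plausible range from 2500 nM to 12000 nM.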

Compound 3, half-maximal effective concentration: 1410 nM
Beside the measured number, compound 3's estimate is 3.9-fold (0.59 log units) above it; the measured number lies below the stated range.
By their numbers in this assay, from the lowest: compounds 3, 1 and 2 (each within the scatter of the next, the first and the last beyond it).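

In this assay, for the compounds shown here, the aryl group on the amide carbonyl is the first place where a single change can be read: phenyl in place of 2,3-dimethylphenyl gives a 2.6-fold lower number from compound 2 to compound 3 (0.41 log units; beyond the scatter), a modest step that lies beyond the scatter. On this one pair, the unsubstituted phenyl is enough at this position, and the two methyl groups bring no gain in this assay. No measurement at hand accounts for the size or direction of this step.

On these data alone, whether one methyl group alone carries the step or both are needed remains open, as does the outcome with a chlorine, a methoxy group or a pyridine ring on the carbonyl carbon. Also open, as far as these compounds go, is how an ester and an amide compare when they carry the same aryl group.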